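The source may hold more compounds than are shown below. What is called first, only, known or untested is meant among the compounds shown, and "the series" means these compounds.

The three measured compounds and their numbers:

compound 1, `Cc1c(OCCCCOCOc2ccc(C(=O)O)cc2)ccc(C(=O)CC2CCCC2)c1O`: 228 nM
compound 2, `Cc1c(OCCCCOc2ccc(C(=O)O)cc2Cl)ccc(C(=O)CC2CCCC2)c1O`: 237 nM
compound 3, `COc1ccc(C(=O)O)cc1OCCCCOc1ccc(C(=O)CC2CCCC2)c(O)c1C`: 425 nM

In an assay on HEK293 cells for positive allosteric modulation of metabotropic glutamate receptor 2 (Rattus norvegicus), read by thallium flux, with a stated time of 2.5 min (on this read-out lower numbers stand for an effect already at smaller amounts and higher numbers for an effect only at larger amounts of compound), compound 3 gives 425 nM, the highest of the three numbers, yet its distance to either neighbour stays within the scatter: there is a 1.8-fold higher number from compound 2 to compound 3 (0.25 log units; within the scatter) and a 1.9-fold higher number from compound 1 to compound 3 (0.27 log units; within the scatter), so no ordering among the three can be read from these values. The remaining step, a 1.0-fold higher number from compound 1 to compound 2 (0.02 log units; within the scatter), is equally flat.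

Compound 4, `Cc1c(OCCCCOc2ccc(C(=O)O)c(Cl)c2)ccc(C(=O)CC2CCCC2)c1O`, arises from compound 3 through (4-carboxy-3-chlorophenyl in place of 5-carboxy-2-methoxyphenyl on an oxygen on a saturated carbon). For the measured compounds named here, no measured pair carries exactly this exchange. Going by the values given here, the steps that bear on it are the three exchanges of the aryl end beyond the chain oxygen, each of which moved the number less than the scatter allows. Among the compounds with values here, all three therefore point the same way: swapping one carboxyaryl end for another, whether with a chlorine or a methoxy group, has so far produced no step that can be told from noise.

On that basis the expectation for compound 4 is a step of no size beyond the scatter, a 1.3-fold lower number from compound 3 to compound 4 (0.12 log units; within the scatter), in no particular direction. Compound 4 is estimated at 320 nM in this assay, within a range from 150 nM to 700 nM.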

Compound 4, half-maximal effective concentration: 510 nM
Estimate against measurement, compound 4: 1.6-fold (0.20 log units) below; the range from low to high includes it.
By their numbers in this assay, from the lowest: compounds 1, 2, 3 and 4 (each within the scatter of the next, the first and the last beyond it).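

In this assay, for the compounds shown here, this change gives the first steps at the aryl end that can be told from the scatter: a 2.2-fold higher number from compound 2 to compound 4 (0.33 log units; beyond the scatter) and a 2.2-fold higher number from compound 1 to compound 4 (0.35 log units; beyond the scatter) are both modest, while a 1.2-fold higher number from compound 3 to compound 4 (0.08 log units; within the scatter) still cannot be told from it. The step from compound 2 is the most telling, since 4-carboxy-2-chlorophenyl and 4-carboxy-3-chlorophenyl differ only in where the chlorine stands, so on this pair the place of the chlorine on the carboxyaryl end, and not only the kind of end group, shows up in the number, though only slightly past the scatter. Nothing given here accounts for this difference.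

Going by these compounds, it remains open whether a fluorine or a methyl group in place of the chlorine of 4-carboxy-3-chlorophenyl would give a step of the same size, as one chlorine pair cannot show whether this holds for other groups. Also open, on these data alone, is whether a tetrazole or a primary amide in place of the carboxylic acid, or a longer chain before the chain oxygen, would move the number further than any of these exchanges at the aryl end.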